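A few compounds are considered here, and "the series" means these few. Any claim that something is new, unique, unknown or untested is made for them only; others in the source may bear on it.

Compound 1 `COc1ccc(C2N=C(SCc3cccc(Cl)c3)NC(C)=C2C(=O)Nc2ccc(Br)cc2)cc1` gives 33.8%
Compound 2 `COc1ccc(C2N=C(SCc3ccc(Cl)cc3)NC(C)=C2C(=O)Nc2ccc(Br)cc2)cc1` gives 29.2%
Compound 3 `CC1=C(C(=O)Nc2ccc([N+](=O)[O-])cc2)C(c2ccc(Br)cc2)N=C(SCc2cccc(Cl)c2)N1` gives 11.8%

These three compounds were examined in a functional assay on the whole organism (artery, strain albino) with Rattus norvegicus as the target, with a stated time of 240 min, at a dose of 10 mg/kg by the oral route; on this read-out higher numbers stand for more inhibition at the one dose given (going by the name of the read-out) and lower numbers for less inhibition. Compound 1 reaches 33.8% in this assay, and compound 2 reaches 29.2%. Between them stands one change, (4-chlorophenyl in place of 3-chlorophenyl on a saturated chain carbon bound to a sulfur), and its step is a number 4.6 percentage points lower from compound 1 to compound 2 (within the scatter), so the two compounds cannot be told apart on this read-out. Compound 3 gives 11.8% in this assay, the lowest of the three numbers, and its distance to compound 2 and to compound 1 lies beyond the scatter in both cases. The difference between the core of compound 3 and the core of compound 1 is not broken down here.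

Compound 4 `CC1=C(C(=O)Nc2ccc([N+](=O)[O-])cc2)C(c2ccc(Br)cc2)N=C(SCc2ccc(Cl)cc2)N1` has not yet been measured in this assay. It differs from compound 3 by 4-chlorophenyl in place of 3-chlorophenyl on a saturated chain carbon bound to a sulfur, the same change that separates compound 1 from compound 2. Since that earlier change gave only a number 4.6 percentage points lower from compound 1 to compound 2 (within the scatter), compound 4 is expected to stay close to compound 3, and the estimated step is a number 2.8 percentage points lower from compound 3 to compound 4 (within the scatter). The reasoning rests on a single measured pair, so the expectation carries wide bounds. For compound 4 in this assay the estimate is 9%, expected to fall between 0% and 22%.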

Compound 4, a percentage reported as inhibition, in the whole organism at one dose (the size of the read-out at that dose, not a potency): 29.7%
For compound 4 the middle estimate is 20.7 percentage points below the measured one; measured number outside the range, above it.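

On the core of compound 3, the same exchange of 3-chlorophenyl for 4-chlorophenyl on a saturated chain carbon bound to a sulfur gives, in this assay, a number 17.9 percentage points higher from compound 3 to compound 4 (beyond the scatter). Going by these compounds alone, the change therefore does not carry over from one core to the other, and the size of its step on one core says little about its step on the other: the same change on two cores in this assay, a number 4.6 percentage points lower (within the scatter) from compound 1 to compound 2 and a number 17.9 percentage points higher (beyond the scatter) from compound 3 to compound 4, 22.5 percentage points apart, beyond the scatter of two such steps This shows that the outcome of the change differs with the core for these four compounds, but it does not show why, and each core offers only one pair, read at a single dose, so no general rule for the series follows from it.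

The core of compound 1 and the core of compound 3 differ in more than one place, and the compounds shown leave open which of those differences goes with the different steps. They also leave open how the result would look with a fluorine or a methyl group in place of the chlorine on the benzyl ring, or with a longer chain joining that ring to the sulfur.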